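This account rests on a few compounds, and the source may have more. Where it says the series, first, only, none or still open, it means among the compounds named here.

In a functional assay on B16 cells (Mus musculus) for inhibition (a higher number here means a weaker inhibitor, a lower number a stronger inhibitor), compound 1 `O=C(/C=C/c1ccc(O)c(O)c1)Nc1ccc([N+](=O)[O-])cc1` gives 1400 nM, compound 2 `Cc1ccccc1CNC(=O)/C=C/c1ccc(O)c(O)c1` gives 20000 nM and compound 3 `Cc1cccc(CNC(=O)/C=C/c2ccc(O)c(O)c2)c1` gives 3000 nM. Compound 3 therefore stands in the middle of the three, with a higher number than compound 1 and a lower number than compound 2, and both gaps exceed the usual scatter of repeated measurements.

The next compound, compound 4 `Cc1ccc(CNC(=O)/C=C/c2ccc(O)c(O)c2)cc1`, has the same atoms as compound 3, joined differently: 4-methylphenyl in place of 3-methylphenyl on a saturated chain carbon bound to an amide-type nitrogen. In words, 4-methylphenyl comes in place of 3-methylphenyl on a saturated chain carbon bound to an amide-type nitrogen.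

For the measured compounds named here, only one measured step bears on this change: a 6.7-fold lower number from compound 2 to compound 3 (0.82 log units; beyond the scatter). It is a modest step of the same kind, with 3-methylphenyl in place of 2-methylphenyl, and it shows that such a swap can shift the number beyond the scatter. Going by the values given here, no measured compound carries the 4-methylphenyl group, and a single step does not give the direction of the next one. The best starting point is therefore compound 3 at 3000 nM, with a wide range on either side. The estimated change is a 1.2-fold lower number from compound 3 to compound 4 (0.08 log units; within the scatter), which means no expected step beyond the scatter. For compound 4 the expected value is 2500 nM, with an estimated range of 700 nM to 9000 nM.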

Compound 4, half-maximal inhibitory concentration: 3700 nM
For compound 4 the middle estimate is 1.5-fold (0.17 log units) below the measured one; the measured number falls inside the stated range.
By their numbers in this assay, from the lowest: compound 1; then compounds 3 and 4 (each within the scatter of the next); then compound 2.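

In this assay, 4-methylphenyl in place of 3-methylphenyl gives a 1.2-fold higher number from compound 3 to compound 4 (0.09 log units; within the scatter), so this swap on the saturated chain carbon bound to an amide-type nitrogen leaves no difference that can be told from the scatter, and compound 3 and compound 4 cannot be ordered. For the compounds shown here, the swap of 4-methylphenyl in place of 2-methylphenyl gives a 5.4-fold lower number from compound 2 to compound 4 (0.73 log units; beyond the scatter), and together with the earlier step this sets compound 2 apart: among the three methylphenyl compounds, the 2-methylphenyl group is the only one whose number differs beyond the scatter from both of the others. No independent measurement here accounts for this pattern.

As far as these compounds go, it remains open whether a different group in the same place, such as 4-ethylphenyl, 4-methoxyphenyl or plain phenyl, would stay level with compound 3 and compound 4 or move away from them. From the compounds shown here alone, it is also open how a longer chain on the amide-type nitrogen, or a carboxylic acid on the ring, would change the number.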